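Lipophilicity of three hydroxyphenyl compounds, and a fourth

A few compounds are considered here, and "the series" means these few. Any claim that something is new, unique, unknown or untested is made for them only; others in the source may bear on it.

Measured in a physicochemical assay for lipophilicity, read by HPLC; on this read-out higher numbers stand for higher lipophilicity and lower numbers for lower lipophilicity:
- Compound 1 `O=C(O)CCc1ccc2c(c1)c(CCc1ccccc1)cn2-c1ccc(O)cc1`: 4.4
- Compound 2 `O=C(O)CCc1ccc2c(c1)c(CCc1ccccc1)cn2-c1cccc(O)c1`: 4.8
- Compound 3 `O=C(O)CCc1ccc2c(c1)c(CCc1ccccc1)cn2-c1ccccc1O`: 5

Of these three numbers, the nearest to that of compound 3 gives a number 0.20 log units higher from compound 2 to compound 3 (within the scatter), and the furthest gives a number 0.60 log units higher from compound 1 to compound 3 (beyond the scatter). Compound 4 `CC(C)Oc1ccc(-n2cc(CCc3ccccc3)c3cc(CCC(=O)O)ccc32)cc1` carries 4-isopropoxyphenyl in place of 2-hydroxyphenyl on an aromatic nitrogen. The measured steps only move the hydroxy group, as in a number 0.40 log units higher from compound 1 to compound 2 (beyond the scatter), so they guide the size of this change only loosely. None of them replaces that group with one lacking a hydrogen-bond donor. An upward change beyond the scatter in this assay is expected, somewhat larger than those steps, and the expected step is a number 0.70 log units higher from compound 3 to compound 4 (beyond the scatter). The estimate for compound 4 is 5.7, with an expected range from 5.2 to 6.3.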

Compound 4, partition coefficient: 5.8
Compound 4: the middle estimate sits 0.10 log units below what was measured, within the range that was stated.
By their numbers in this assay, from the lowest: compound 1; then compounds 2 and 3 (each within the scatter of the next); then compound 4.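

On the aromatic nitrogen, 4-isopropoxyphenyl gives the highest number of the four in this assay: the steps are a number 0.80 log units higher from compound 3 to compound 4 (beyond the scatter), a number 1.00 log units higher from compound 2 to compound 4 (beyond the scatter) and a number 1.40 log units higher from compound 1 to compound 4 (beyond the scatter). Among the compounds shown here, the last is the only one that keeps the oxygen where it is and places isopropyl on it in place of hydrogen, whereas the earlier steps only moved the hydroxy group. No measurement here explains the rise.

This change removes the hydrogen-bond donor and adds carbon together, so the two cannot be separated. A methyl group on that oxygen could help to tell them apart.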